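Trimming the propargyl ester of compound 1 to the free acid

The source may report more compounds than this note shows. Statements on the series, on what has been measured and on what is new or still open speak of the compounds shown alone.

compound 1 `C#CCOC(=O)/C(C)=C/CC/C(C)=C/CC/C(C)=C/CC[C@@H]1[C@@]2(C)CCC(=O)C(C)(C)[C@H]2CC[C@@]1(C)O`: 46100 nM
compound 2 `C/C(=C\CC/C(C)=C/CC[C@@H]1[C@@]2(C)CCC(=O)C(C)(C)[C@H]2CC[C@@]1(C)O)CC/C=C(\C)C(=O)OCc1cn(-c2cccc(F)c2)nn1`: > 150000 nM (a limit)
compound 3 `C/C(=C\CC/C(C)=C/CC[C@@H]1[C@@]2(C)CCC(=O)C(C)(C)[C@H]2CC[C@@]1(C)O)CC/C=C(\C)C(=O)OCc1cn(-c2ccc(Cl)cc2)nn1`: > 150000 nM (a limit)

Within the data shown here, in a functional assay on DU-145 cells (Homo sapiens) for antiproliferative activity, read by MTT assay, with a stated time of 48 h (on this read-out lower numbers stand for stronger inhibition and higher numbers for weaker inhibition), compound 1 gives 46100 nM, the only real number among the three. Compound 2 reaches only a limit, > 150000 nM. Compound 3 likewise reaches only a limit, > 150000 nM. Compound 4 `C/C(=C\CC/C(C)=C/CC[C@@H]1[C@@]2(C)CCC(=O)C(C)(C)[C@H]2CC[C@@]1(C)O)CC/C=C(\C)C(=O)O` differs from compound 1 as follows: hydrogen in place of propargyl on an oxygen next to a carbonyl group. Among the measured compounds shown here, no measured step removes the propargyl outright; the nearest are an at least 3.2-fold higher number from compound 1 to compound 2 (0.51 log units; beyond the scatter) and an at least 3.2-fold higher number from compound 1 to compound 3 (0.51 log units; beyond the scatter), both ending at the limit of > 150000 nM in this assay, at which 2 of the 3 values shown sit. Those steps enlarge the ester rather than strip it, so they do not settle what the bare acid will do. Compound 4 is expected to give about 65000 nM, between 20000 nM and 200000 nM, so a 1.4-fold higher number from compound 1 to compound 4 (0.15 log units; within the scatter) is expected.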

Compound 4, half-maximal inhibitory concentration: > 150000 nM
Compound 4 ended at the assay's limit; the forecaster's own chance of this, stated with the estimate: 35%; at least 2.3-fold (0.36 log units) between middle value and limit.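

In this assay, replacing the propargyl group with hydrogen weakens the compound, with an at least 3.2-fold higher number from compound 1 to compound 4 (0.51 log units; beyond the scatter). Among these compounds, the bare carboxy group therefore joins the two larger triazole esters in doing worse than the propargyl ester, which is the only one of the four compounds to give a real number. Compound 4 gives only a limit, as do compounds 2 and 3, so the steps among these three cannot be read: the limit of > 150000 nM in this assay, at which 3 of the 4 values shown sit.

From the compounds shown here alone, it remains open whether a methyl ester or a simple amide in place of the propargyloxy group would keep the activity of compound 1.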